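The source may hold more compounds than are shown below. What is called first, only, known or untested is meant among the compounds shown, and "the series" means these compounds.

Compound 1 `COc1cc(/C=C/c2c[nH]c3ccccc23)cc(OC)c1OC`: 3230 nM
Compound 2 `COc1cc(/C=C\c2c[nH]c3ccccc23)cc(OC)c1OC`: 3230 nM

Both values come from a functional assay on HeLa cells (Homo sapiens) for inhibition; on this read-out lower numbers stand for stronger inhibition and higher numbers for weaker inhibition. Going by the values given here, compound 2, at 3230 nM, stands level with compound 1, its only measured neighbour. What sets the two apart is the fact that compounds 1 and 2 differ only in the configuration as drawn.

The next compound, compound 3 `COc1cc(/C=C\c2cn(C)c3ccccc23)cc(OC)c1OC`, keeps the double bond of compound 2 and changes a different place: methyl in place of hydrogen on an aromatic nitrogen. In words, this is methyl in place of hydrogen on an aromatic nitrogen.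

Among the compounds with values here, the only measured step, no change at the digits printed from compound 1 to compound 2 (within the scatter), concerns the double bond and leaves that nitrogen untouched, so it gives no direct measure of this new change. Within the data shown here, no measured compound carries a methyl there, so the direction cannot be argued with any confidence. Among the measured compounds shown here, the cautious expectation in this assay is therefore no step clearly beyond the scatter, though a wide range must stay open.

The expected change is a 1.2-fold lower number from compound 2 to compound 3 (0.06 log units; within the scatter). For compound 3 the estimate is 2800 nM, with an expected range from 500 nM to 12000 nM.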

Compound 3, half-maximal inhibitory concentration: 3090 nM
For compound 3 the middle estimate is 1.1-fold (0.04 log units) below the measured one; the range from low to high includes it.
By their numbers in this assay, from the lowest: compounds 3, 1 and 2 (each within the scatter of the next).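

In this assay, putting methyl in place of hydrogen on the aromatic nitrogen gives a 1.0-fold lower number from compound 2 to compound 3 (0.02 log units; within the scatter) and so leaves compound 3 level with compound 2. Going by these compounds alone, this is the first measured information about this nitrogen, since the earlier pair differed only at the double bond. It shows that, with the double bond drawn Z, a compound carrying a hydrogen on this nitrogen and one carrying a methyl there cannot be told apart in this assay, so a small carbon group is accepted at this position without any step beyond the usual scatter. Nothing available explains why the two read the same.

As far as these compounds go, what remains open is whether this tolerance extends past a single carbon: an ethyl group, a longer chain such as butyl, a benzyl group or an acetyl group on the same nitrogen could read quite differently. From the compounds shown here alone, it is also open whether methyl at this nitrogen would read the same with the double bond drawn E, as in compound 1, since a result on one double-bond form need not carry over to the other.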